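Dropping the difluoromethyl from the weakest compound in the series

The source may hold more compounds than are shown below. What is called first, only, known or untested is meant among the compounds shown, and "the series" means these compounds.

Of the compounds shown here, three have been measured in an assay on Jurkat E6.1 cells for inhibition of histone deacetylase 4 (Homo sapiens), read by fluorescence; a lower number here means a stronger inhibitor, a higher number a weaker inhibitor. Going by the values given here, compound 1 `C[C@H](CN1CCCC(C)(C)C1)NC(=O)c1ccc(-c2noc(C(F)(F)F)n2)cc1` gives 10 nM, compound 2 `C[C@H](CN1CCC(F)CC1)NC(=O)c1ccc(-c2noc(C(F)(F)F)n2)cc1` gives 100 nM, and the only change between them, a 10-fold higher number from compound 1 to compound 2 (1.00 log units; beyond the scatter), concerns the saturated amine ring. Compound 3 `CCCN(CCC)C[C@@H](C)NC(=O)c1ccc(-c2noc(C(F)F)n2)cc1` gives 19000 nM and stands highest of the three numbers, a step beyond the scatter from both compound 2 and compound 1.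

Compound 4 `CCCN(CCC)C[C@@H](C)NC(=O)c1ccc(-c2ncon2)cc1` differs from compound 3 by hydrogen in place of difluoromethyl on an aromatic carbon. Among the compounds with values here, no measured step touches this part of the molecule: the one step on record, between compound 1 and compound 2, alters the amine ring, while the pair compound 2 and compound 3 changes both the amine and the oxadiazole substituent at once, so their two values alone cannot separate the two effects. For compound 4 the expectation therefore rests on the weak starting point of compound 3 at 19000 nM and on the absence of any guidance from the measured steps. He expects compound 4 to read somewhat higher, by about a 2.1-fold higher number from compound 3 to compound 4 (0.32 log units; beyond the scatter), with wide uncertainty. His estimate for compound 4 in this assay is 40000 nM, between 10000 nM and 150000 nM.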

Compound 4, half-maximal inhibitory concentration: > 50000 nM
Compound 4: a limit, no number; the forecaster's own chance of this, stated with the estimate: 40%; middle value at least 1.2-fold (0.09 log units) away from the limit.
By their numbers in this assay, from the lowest: compound 1; then compound 2; then compound 3. At a limit, above all of these: compound 4.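

In this assay, replacing the 5-(difluoromethyl)-1,2,4-oxadiazol-3-yl group with 1,2,4-oxadiazol-3-yl, with the rest of the molecule unchanged, gives an at least 2.6-fold higher number from compound 3 to compound 4 (0.42 log units; beyond the scatter). Going by these compounds alone, this is the first measured step at this aromatic carbon, next to the ring nitrogen and next to the ring oxygen, and it shows that the substituent there matters on its own, apart from any change in the amine, with hydrogen reading worse than difluoromethyl even from a weak starting point. Compound 4 sits at a limit of the assay, not at a number, so this step fixes only a lower bound on the size of the change: the limit of > 50000 nM in this assay, at which 1 of the 4 values shown sits.

From the compounds shown here alone, how far a methyl, a chlorine or a trifluoromethyl on this carbon would move the number with the amine of compound 3 held fixed remains open. Compound 1 and compound 2 carry trifluoromethyl here, but they also differ from compound 3 in the amine, so the compounds shown do not separate what each of the two places contributes.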